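Fluoro for chloro on the aryl amide of a quinazoline series

A few compounds are considered here, and "the series" means these few. Any claim that something is new, unique, unknown or untested is made for them only; others in the source may bear on it.

Compound 1 `O=C(CSc1nc(Nc2ccccc2)c2ccccc2n1)Nc1cccc(F)c1` and compound 2 `O=C(CSc1nc(Nc2ccccc2)c2ccccc2n1)Nc1cccc(Cl)c1` share one core; compound 3 `C=CC(=O)Nc1cccc(NC(=O)CSc2nc(Nc3ccc(Cl)c(Cl)c3)c3ccccc3n2)c1` and compound 4 `C=CC(=O)Nc1cccc(NC(=O)CSc2nc(Nc3ccc(F)c(Cl)c3)c3ccccc3n2)c1` share another, and the difference between the two cores is not broken down here. In a functional assay on MGC-803 cells (Homo sapiens) for inhibition, read by MTT assay, with a stated time of 72 h (a higher number here means a weaker inhibitor, a lower number a stronger inhibitor), compound 1 gives 12700 nM and compound 2 gives 14300 nM. The step of a 1.1-fold lower number from compound 2 to compound 1 (0.05 log units; within the scatter) is the change (fluoro in place of chloro on an aromatic carbon). For compound 3 only a limit is reported in this assay, > 50000 nM, as noted in the limit of > 50000 nM in this assay, at which 1 of the 3 values shown sits.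

The change from compound 3 to compound 4 is fluoro in place of chloro on an aromatic carbon. It is the same kind of change as that from compound 2 to compound 1, but the surroundings differ: in compound 1 the fluoro is meta to a large group, whereas in compound 4 it is ortho to a chloro group and para to a large group. Since the measured step of a 1.1-fold lower number from compound 2 to compound 1 (0.05 log units; within the scatter) stayed within the scatter, a step of similar size is expected here, a step that the limit leaves unreadable from compound 3 to compound 4, and compound 3 already sits at the limit. Compound 4 is therefore estimated at 60000 nM in this assay, most likely again reported only as a limit.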

Compound 4, half-maximal inhibitory concentration: 7850 nM
The estimate for compound 4 lay 7.6-fold (0.88 log units) above the measured number; the measured number lies below the stated range.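

In this assay, fluoro in place of chloro gives an at least 6.3-fold lower number from compound 3 to compound 4 (0.80 log units; beyond the scatter), whereas on the other core it gives a 1.1-fold lower number from compound 2 to compound 1 (0.05 log units; within the scatter), so the change does not carry over at one size between these two cores: the same change on two cores in this assay, a 1.1-fold lower number (0.05 log units; within the scatter) from compound 2 to compound 1 and an at least 6.3-fold lower number (0.80 log units; beyond the scatter) from compound 3 to compound 4, at least 5.6-fold (0.75 log units) apart, beyond the scatter of two such steps

The step from 3,4-dichlorophenyl to 3-chloro-4-fluorophenyl has only a lower bound, since compound 3 is reported as a limit and not as a number: the limit of > 50000 nM in this assay, at which 1 of the 4 values shown sits.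

With a single pair on each core, this does not show a rule for the series, nor does it show whether the gap follows from the place of the change on the ring or from another part of the two cores.

Still open, on these data alone, is how the same change behaves on the core of compound 1 with a chloro group kept on the ring, and on the core of compound 4 with that chloro group gone. Also open, as far as these compounds go, is how a methoxy or a nitrile would compare with fluoro in the same place on the core of compound 4.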